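Tert-butyl for bromo on the triazolyl aryl ester

The compounds below may be only part of what the source reports. "The series", "measured", "known", "first", "only" and "open" are said of these compounds alone.

Working notes on a series built on one shared core, carried as esters of a long chain alcohol. Compound 1 `C/C(=C\CC/C(C)=C/CC[C@@H]1[C@@]2(C)CCC(=O)C(C)(C)[C@H]2CC[C@@]1(C)O)CC/C=C(\C)C(=O)OCc1cn(C[C@@H]2O[C@H](n3ccc(=O)[nH]c3=O)C[C@H]2O)nn1` carries a nucleoside-bearing triazole and gives 75800 nM in a functional assay on U-87MG ATCC cells for antiproliferative activity against U-87 MG (Homo sapiens), read by MTT assay, with a stated time of 48 h; a higher number here means a weaker inhibitor, a lower number a stronger inhibitor. Compound 2 `C#CCOC(=O)/C(C)=C/CC/C(C)=C/CC/C(C)=C/CC[C@@H]1[C@@]2(C)CCC(=O)C(C)(C)[C@H]2CC[C@@]1(C)O` is the ethynyl ester; in this assay compound 2 reaches only the limit of > 150000 nM. Compound 3 `C/C(=C\CC/C(C)=C/CC[C@@H]1[C@@]2(C)CCC(=O)C(C)(C)[C@H]2CC[C@@]1(C)O)CC/C=C(\C)C(=O)OCc1cn(-c2ccc(Br)cc2)nn1` carries the 1-(4-bromophenyl)-1H-1,2,3-triazol-4-yl group; in this assay compound 3 likewise reaches only the limit of > 150000 nM. The step that the two limits leave unreadable from compound 2 to compound 3 is therefore not readable as a size. Compound 3 thus sits at the weak end of what is shown, at the same limit as compound 2, and only compound 1 gives a number.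

Compound 4 `C/C(=C\CC/C(C)=C/CC[C@@H]1[C@@]2(C)CCC(=O)C(C)(C)[C@H]2CC[C@@]1(C)O)CC/C=C(\C)C(=O)OCc1cn(-c2ccc(C(C)(C)C)cc2)nn1` differs from compound 3 by tert-butyl in place of bromo on an aromatic carbon. Within the data shown here, no measured step bears on this change: the only step recorded, from compound 2 to compound 3, is itself unreadable, and the evidence the limit of > 150000 nM in this assay, at which 2 of the 3 values shown sit, says only that two of the three values sit at a limit. Compound 4 is therefore expected to stay near that limit, with the step of a number no higher from compound 3 to compound 4 (the limit leaves the size open) read as none beyond the scatter. The estimate for compound 4 in this assay is 150000 nM, within 50000 nM to 450000 nM.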

Compound 4, half-maximal inhibitory concentration: > 150000 nM
Compound 4 gave a limit, no number; the forecaster's own chance of this, stated with the estimate: 70%; the middle value lies on the limit itself.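

Compound 3 and compound 4 both give only a limit in this assay, and no new step can be read from this pair: the limit of > 150000 nM in this assay, at which 3 of the 4 values shown sit.

The compounds shown leave open how tert-butyl and bromo compare on the aryl triazole ester, and how far below the limit, if at all, either compound lies.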